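Changing the aryl group on a thiocarbonyl nitrogen

A few compounds are considered here, and "the series" means these few. Any claim that something is new, unique, unknown or untested is made for them only; others in the source may bear on it.

Compound 3 `NC(=O)c1c(NC(=O)c2ccccc2Cl)sc2c1CCN(C(=S)Nc1cccc3ccccc13)C2` was tested in a functional assay on HeLa cells (Homo sapiens) for antiproliferative activity, with a stated time of 24 h (on this read-out higher numbers stand for weaker inhibition and lower numbers for stronger inhibition), where compound 3 gives 30800 nM. Among the numbers shown this is the highest of two, with compound 2 `NC(=O)c1c(NC(=O)c2ccccc2Cl)sc2c1CCN(Cc1c(Cl)cccc1Cl)C2` nearest at 28800 nM, a gap that lies within the scatter. Compound 1 `NC(=O)c1c(NC(=O)c2ccccc2Cl)sc2c1CCN(Cc1ccc(Cl)cc1)C2` reaches only a limit, > 50000 nM. Within the data shown here, the single measured step, an at least 1.7-fold lower number from compound 1 to compound 2 (0.23 log units; that floor lies within the scatter), concerns a saturated chain carbon bound to an amine nitrogen in a ring, not the position changed here. Compound 4 `CSc1ccccc1NC(=S)N1CCc2c(sc(NC(=O)c3ccccc3Cl)c2C(N)=O)C1` differs from compound 3 by 2-(methylsulfanyl)phenyl in place of naphthalen-1-yl on an amide-type nitrogen. Among the measured compounds shown here, no measured step bears on this position, so no step beyond the scatter is expected, and the estimate amounts to a 1.0-fold lower number from compound 3 to compound 4 (0.01 log units; within the scatter). Compound 4 is therefore expected to give about 30000 nM in this assay, between 10000 nM and 90000 nM.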

Compound 4, half-maximal inhibitory concentration: 43600 nM
The estimate for compound 4 lay 1.5-fold (0.16 log units) below the measured number; low and high end bracket the measured number.
By their numbers in this assay, from the lowest: compounds 2, 3 and 4 (each within the scatter of the next). At a limit, above all of these: compound 1.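

In this assay, among these compounds, 2-(methylsulfanyl)phenyl in place of naphthalen-1-yl on the amide-type nitrogen gives a 1.4-fold higher number from compound 3 to compound 4 (0.15 log units; within the scatter), so the first reading at this position shows no change beyond the scatter, even with one aromatic ring fewer and a sulfur added. Against the dichlorinated side group on the amine nitrogen in a ring, the change gives a 1.5-fold higher number from compound 2 to compound 4 (0.18 log units; within the scatter). Against compound 1, a limit, only a floor can be read, an at least 1.1-fold lower number from compound 1 to compound 4 (0.05 log units; that floor lies within the scatter): the limit of > 50000 nM in this assay, at which 1 of the 4 values shown sits.

Going by these compounds, it remains open what an amine or a carboxylic acid would do in place of the methylsulfanyl group. On these data alone, whether any group at this position can bring the number clearly under those of compounds 2, 3 and 4 also remains open.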